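The source may hold more compounds than are shown below. What is called first, only, known or untested is meant among the compounds shown, and "the series" means these compounds.

Working notes on the urea series. Compound 1 `CC(C)c1ccc(C2(CNC(=O)Nc3c(C(C)C)cccc3C(C)C)CCCC2)cc1` sets the reference point and in an assay on microsomes for inhibition of acyl-CoA:cholesterol acyltransferase (Oryctolagus cuniculus) (on this read-out higher numbers stand for weaker inhibition and lower numbers for stronger inhibition), compound 1 gives 48 nM. Compound 2 `CC(C)c1cccc(C(C)C)c1NC(=O)NCC1(c2ccc([N+](=O)[O-])cc2)CCCC1` gives 131 nM, the step being a 2.7-fold higher number from compound 1 to compound 2 (0.44 log units; beyond the scatter). Compound 3 `CC(C)c1cccc(C(C)C)c1NC(=O)NCC1(c2cccc(C(=O)O)c2)CCCC1` gives 620 nM and stands highest of the three measured numbers, with compound 2 nearest and compound 1 furthest; the steps are a 13-fold higher number from compound 1 to compound 3 (1.11 log units; beyond the scatter) and a 4.7-fold higher number from compound 2 to compound 3 (0.68 log units; beyond the scatter), so each exchange that brings in the 3-carboxyphenyl raises the number beyond the scatter.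

Compound 4 `CC(C)c1cccc(C(C)C)c1NC(=O)NCC1(c2cccc(CO)c2)CCCC1` differs from compound 3 by hydroxymethyl in place of carboxy on an aromatic carbon. Among the compounds with values here, no measured step alters a carboxy directly, so the bearing of the earlier steps is indirect: both steps leading to compound 3 rose when the carboxy arrived, which points to the number falling again when it leaves. Since the hydroxymethyl keeps one donor and one acceptor, a partial return toward compound 2 is expected rather than a full one, giving an expected step of a 2.5-fold lower number from compound 3 to compound 4 (0.39 log units; beyond the scatter). Compound 4 is therefore estimated at 250 nM, with a range from 90 nM to 700 nM.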

Compound 4, half-maximal inhibitory concentration: 15 nM
Compound 4: the middle estimate sits 17-fold (1.22 log units) above what was measured, and the stated range ends above it.
By their numbers in this assay, from the lowest: compound 4; then compound 1; then compound 2; then compound 3.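

In this assay hydroxymethyl in place of carboxy on this aromatic carbon gives a 41-fold lower number from compound 3 to compound 4 (1.62 log units; beyond the scatter), a large change even though the two groups match in hydrogen-bond donor and acceptor counts. The 3-(hydroxymethyl)phenyl also passes both earlier aryl groups, with an 8.7-fold lower number from compound 2 to compound 4 (0.94 log units; beyond the scatter) and a 3.2-fold lower number from compound 1 to compound 4 (0.51 log units; beyond the scatter), so compound 4 has the lowest number of the four and a substituted 3-position on this phenyl can go with stronger inhibition than the 4-isopropylphenyl of compound 1 gives. Nothing measured here accounts for the size of these steps.

As far as these compounds go, it remains open whether a hydroxyethyl, a methoxymethyl or an aminomethyl on this aromatic carbon would hold the number of compound 4. From the compounds shown here alone, it is also open whether the hydroxymethyl would give a similar number on another carbon of the ring.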